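The source may report more compounds than this note shows. Statements on the series, on what has been measured and on what is new or still open speak of the compounds shown alone.

In a functional assay on HeLa cells (Homo sapiens) for antiproliferative activity, read by MTT assay, with a stated time of 72 h (a higher number here means a weaker inhibitor, a lower number a stronger inhibitor), compound 1 `C/C=C/C(=O)Nc1cccc(Oc2nc(Nc3ccn(C)n3)nc3c2CSCC3)c1` is reported only as a limit, > 50000 nM. Compound 2 `CCC/C=C/C(=O)Nc1cccc(Oc2nc(Nc3ccn(C)n3)nc3c2CSCC3)c1` gives a true number, 17000 nM. Among the measured compounds shown here, the one measured step, an at least 2.9-fold lower number from compound 1 to compound 2 (0.46 log units; beyond the scatter), comes from ethyl in place of hydrogen on a saturated chain carbon bound to a double-bonded chain carbon. Compound 3 `C/C=C/C(=O)Nc1cccc(Oc2nc(Nc3ccc(OC)nc3)nc3c2CSCC3)c1` changes a different part of the molecule: 6-methoxypyridin-3-yl in place of 1-methyl-1H-pyrazol-3-yl on a nitrogen on an aromatic ring, with 6-methoxypyridin-3-yl in place of 1-methyl-1H-pyrazol-3-yl on a nitrogen on an aromatic ring. For the measured compounds named here, no measured step touches that place, so the step to compound 2 serves only as a rough guide to size. A similarly modest move toward a lower number is expected, although another limit remains possible. The expected change is an at least 2.0-fold lower number from compound 1 to compound 3 (0.30 log units; that floor lies within the scatter). For compound 3, the estimated value is 25000 nM, with an expected range from 7000 nM to 50000 nM.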

Compound 3, half-maximal inhibitory concentration: 16500 nM
Estimate against measurement, compound 3: 1.5-fold (0.18 log units) above; the range from low to high includes it.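

In this assay, the earlier step changed only the chain, and this result shows that the group on the nitrogen on the aromatic ring matters too: 6-methoxypyridin-3-yl in place of 1-methyl-1H-pyrazol-3-yl gives an at least 3.0-fold lower number from compound 1 to compound 3 (0.48 log units; beyond the scatter). A true number can therefore be reached through this position alone, with the short chain of compound 1 left as it is. The real size of the step stays unknown, because compound 1 is known only as a limit, which makes the step a floor: the limit of > 50000 nM in this assay, at which 1 of the 3 values shown sits.

The change swaps the whole ring, and the compounds shown do not separate the effect of the methoxy group from that of the six-membered ring itself. Still open, on these data alone, are how a plain phenyl group would read at this nitrogen, and whether the longer chain of compound 2 would add to the effect of 6-methoxypyridin-3-yl.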